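The source may report more compounds than this note shows. Statements on the series, on what has been measured and on what is new or still open speak of the compounds shown alone.

Compounds measured so far in a functional assay on MCF7 cells (Homo sapiens) for antiproliferative activity, read by MTT assay, with a stated time of 24 h; a lower number here means a stronger inhibitor, a higher number a weaker inhibitor:

- compound 1, `COC(=O)c1scc(-c2ccc(NC(=O)c3cc(I)ccc3F)cc2)c1OC`: 22500 nM
- compound 2, `COC(=O)c1scc(-c2ccc(NC(=O)c3cccc(C(F)(F)F)c3)cc2)c1OC`: 26200 nM
- compound 3, `COC(=O)c1scc(-c2ccc(NC(=O)c3ccccn3)cc2)c1OC`: 19200 nM

Compound 3 has the lowest of the three numbers, but the gaps to the others are small: a 1.2-fold lower number from compound 1 to compound 3 (0.07 log units; within the scatter) and a 1.4-fold lower number from compound 2 to compound 3 (0.14 log units; within the scatter), both within the scatter. On these numbers the three compounds cannot be separated.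

Compound 4, `COC(=O)c1scc(-c2ccc(NC(=O)c3ccc(C(F)(F)F)cc3)cc2)c1OC`, has not yet been measured. It differs from compound 3 in one place: 4-(trifluoromethyl)phenyl in place of pyridin-2-yl on a carbonyl carbon

For the measured compounds named here, the steps that bear on this change are those in which the group on the carbonyl carbon was exchanged while the shared core was kept: a 1.2-fold higher number from compound 1 to compound 2 (0.07 log units; within the scatter), a 1.2-fold lower number from compound 1 to compound 3 (0.07 log units; within the scatter) and a 1.4-fold lower number from compound 2 to compound 3 (0.14 log units; within the scatter). None of them moved the number beyond the scatter, and compound 2, which carries the 3-(trifluoromethyl)phenyl group, gives 26200 nM. For the change to 4-(trifluoromethyl)phenyl no step beyond the scatter is therefore expected in this assay. Compound 4 is estimated at 24000 nM, with a range of 12000 nM to 48000 nM. This estimate means a step of a 1.3-fold higher number from compound 3 to compound 4 (0.10 log units; within the scatter), expected to lie within the scatter.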

Compound 4, half-maximal inhibitory concentration: 24600 nM
Estimate against measurement, compound 4: 1.0-fold (0.01 log units) below; the range from low to high includes it.
By their numbers in this assay, from the lowest: compounds 3, 1, 4 and 2 (each within the scatter of the next).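

In this assay the 4-(trifluoromethyl)phenyl group on the carbonyl carbon does not separate from any of the groups tried there so far (a 1.3-fold higher number from compound 3 to compound 4 (0.11 log units; within the scatter); a 1.1-fold higher number from compound 1 to compound 4 (0.04 log units; within the scatter)). For the compounds shown here, the exchange of 3-(trifluoromethyl)phenyl for 4-(trifluoromethyl)phenyl, a pair of names the earlier compounds did not offer, also stays within the scatter (a 1.1-fold lower number from compound 2 to compound 4 (0.03 log units; within the scatter)), so all four compounds remain inseparable at this position. No measurement at hand offers an explanation for this flat reading.

Still open, on these data alone, is whether any group on this carbonyl carbon moves the number beyond the scatter, for instance a phenyl group carrying an amine or a carboxylic acid, or a longer alkyl chain. Also open, as far as these compounds go, is how the number responds to a change elsewhere in the shared core.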